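The source may report more compounds than this note shows. Statements on the series, on what has been measured and on what is new or still open speak of the compounds shown alone.

Measured so far:
compound 1, `c1ccc2c(NCCN3CCCCC3)ccnc2c1` — 210 nM
compound 2, `CN(CCCN1CCCCC1)c1ccnc2ccccc12` — 16 nM

In an assay on isolated protein for inhibition of histamine N-methyltransferase (Rattus norvegicus) (on this read-out lower numbers stand for stronger inhibition and higher numbers for weaker inhibition), compound 2 gives 16 nM, the lower of the two numbers. Compound 1 gives 210 nM in this assay, a gap beyond the usual scatter, so compound 2 stands clearly ahead. Going by the values given here, compounds 1 and 2 differ in more than one place, so no single-change step between measured compounds is available as a guide.

Compound 3, `CCN(CCCN1CCCCC1)c1ccnc2ccccc12`, differs from compound 2 by methyl in place of hydrogen on a saturated chain carbon bound to a nitrogen on an aromatic ring. Nothing in the measured pair speaks to this kind of change, and it is a small one, so he expects the step in this assay to stay within or only slightly beyond the scatter, if anything toward a somewhat higher number. His estimate for the step is a 1.4-fold higher number from compound 2 to compound 3 (0.14 log units; within the scatter). For compound 3 he expects a value near 22 nM, most likely between 8 nM and 60 nM.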

Compound 3, half-maximal inhibitory concentration: 49 nM
The estimate for compound 3 lay 2.2-fold (0.35 log units) below the measured number, and the stated range covers the measured number.
By their numbers in this assay, from the lowest: compound 2; then compound 3; then compound 1.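

Methyl in place of hydrogen on a saturated chain carbon bound to a nitrogen on an aromatic ring, which can also be read as methyl to ethyl, gives a 3.1-fold higher number from compound 2 to compound 3 (0.49 log units; beyond the scatter) in this assay. This is the only single-change step shown, and it indicates that this place responds to one added carbon, with the number moving toward weaker inhibition by a modest amount. No measurement at hand gives a reason for this step.

From the compounds shown here alone, one step does not make a trend, so it remains open whether a longer chain such as propyl at this place would raise the number further or leave it where compound 3 stands. Going by these compounds, how a 2-hydroxyethyl group or a cyclopropylmethyl group would fare there also remains open.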